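The source may hold more compounds than are shown below. What is called first, only, known or untested is meant among the compounds shown, and "the series" means these compounds.

Values so far in a functional assay on SK-BR-3 cells (Homo sapiens) for cytotoxicity, read by sulforhodamine B assay, with a stated time of 3 days; a higher number here means that more compound is needed for the effect, a lower number that less compound is needed
- compound 1 `COc1c(-c2occ(C)c2C(=O)O)ccc2c1CCCC2(C)C` gives 25.5 uM
- compound 2 `COc1c(-c2occ(C)c2COC(C)=O)ccc2c1CCCC2(C)C` gives 14 uM
- compound 3 `CCOc1c(-c2occ(C)c2CO)ccc2c1CCCC2(C)C` gives 9.9 uM

Compound 3 (9.9 uM) lies within the scatter of compound 2 (14 uM). Compared with compound 1 (25.5 uM), it sits on the lower side, beyond the scatter.

Compound 4 `COc1c(-c2occ(C)c2CO)ccc2c1CCCC2(C)C` differs from compound 3 by hydrogen in place of methyl on a saturated chain carbon bound to an oxygen on an aromatic ring and carries hydrogen in place of methyl on a saturated chain carbon bound to an oxygen on an aromatic ring, which turns ethoxy to methoxy. Among the compounds with values here, the only single-place step measured (a 1.8-fold lower number from compound 1 to compound 2 (0.26 log units; within the scatter)) stays within the scatter and concerns acetoxymethyl in place of carboxy on an aromatic carbon, a different change at a different place. Within the data shown here, no measured step touches the ethoxy group, so the data give no direction here. In this assay no shift beyond the scatter is expected, and the value of compound 3 (9.9 uM) serves as the anchor. The expected step (a 1.1-fold higher number from compound 3 to compound 4 (0.05 log units; within the scatter)) stays within the scatter. Compound 4 is estimated at 11 uM (expected range 5.5 uM to 22 uM).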

Compound 4, concentration for half-maximal effect: 23.7 uM
Compound 4: the middle estimate sits 2.2-fold (0.33 log units) below what was measured; measured number above the stated range.
By their numbers in this assay, from the lowest: compounds 3, 2, 4 and 1 (each within the scatter of the next, the first and the last beyond it).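

In this assay, within the data shown here, the change from ethoxy to methoxy gives the first step beyond the scatter at a saturated chain carbon bound to an oxygen on an aromatic ring (a 2.4-fold higher number from compound 3 to compound 4 (0.38 log units; beyond the scatter)), so this place responds, though modestly. Among these compounds, with methoxy held, neither hydrogen in place of acetyl on an oxygen on a saturated carbon (a 1.7-fold higher number from compound 2 to compound 4 (0.23 log units; within the scatter)) nor the change from carboxy to hydroxymethyl (a 1.1-fold lower number from compound 1 to compound 4 (0.03 log units; within the scatter)) moves the number beyond the scatter, leaving the ethoxy to methoxy change as the only single-place step that does. Nothing available bears on the reason for this step.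

Open, as far as these compounds go, is whether a longer chain, such as propoxy, extends the step seen between methoxy and ethoxy. Also open, from the compounds shown here alone, is whether ethoxy has the same effect alongside the acetoxymethyl of compound 2 or the carboxy of compound 1.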